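Cytotoxicity Outlook for an Aryl Ester Analogue

A few compounds are considered here, and "the series" means these few. Any claim that something is new, unique, unknown or untested is made for them only; others in the source may bear on it.

Three compounds sharing one core were tested in an ADME assay on Vero cells (Chlorocebus sabaeus) for cytotoxicity, read by MTT assay, with a stated time of 48 h; on this read-out lower numbers stand for stronger inhibition and higher numbers for weaker inhibition. Compound 1, `CC(C)S(=O)(=O)OC1CCC(CN2CCN(c3cc(=O)c4cc(C(F)(F)F)cc([N+](=O)[O-])c4s3)CC2)CC1`, gives in this assay only a limit, > 64 ug/mL. Compound 2, `O=C(OC1CCC(CN2CCN(c3cc(=O)c4cc(C(F)(F)F)cc([N+](=O)[O-])c4s3)CC2)CC1)c1ccc(F)cc1`, likewise gives only a limit, > 64 ug/mL. Compound 3, `CS(=O)(=O)OC1CCC(CN2CCN(c3cc(=O)c4cc(C(F)(F)F)cc([N+](=O)[O-])c4s3)CC2)CC1`, also gives only a limit, > 64 ug/mL. Compound 3 therefore stands nowhere distinct: its value is a limit, and the two other values shown are limits as well, all sitting at the limit of > 64 ug/mL in this assay, at which 3 of the 3 values shown sit. The three steps among them, a step that the two limits leave unreadable from compound 1 to compound 2, a step that the two limits leave unreadable from compound 1 to compound 3 and a step that the two limits leave unreadable from compound 2 to compound 3, are unreadable for this reason.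

Compound 4, `O=C(OC1CCC(CN2CCN(c3cc(=O)c4cc(C(F)(F)F)cc([N+](=O)[O-])c4s3)CC2)CC1)c1cccc(C(F)(F)F)c1`, differs from compound 3 as follows: (3-(trifluoromethyl)phenyl)carbonyl in place of methylsulfonyl on an oxygen on a saturated carbon. For the measured compounds named here, the step that bears most closely on this change is the one from compound 3 to compound 2, where a benzoyl-type ester entered in place of methylsulfonyl, yet the step that the two limits leave unreadable from compound 2 to compound 3 read in the other direction is unreadable, so no size or direction beyond the scatter can be expected in this assay. Compound 4 is expected to sit at the limit as well, estimated at 100 ug/mL with a range from 40 ug/mL to 300 ug/mL, the expected step being a step that the limit leaves unreadable from compound 3 to compound 4.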

Compound 4, half-maximal inhibitory concentration: > 64 ug/mL
Compound 4: only a limit was reported; the forecaster's own chance of this, stated with the estimate: 85%; the middle value is on the limit's open side.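

In this assay compound 4 gives > 64 ug/mL, which is a limit and not a number. Its steps from compound 1, compound 2 and compound 3 therefore cannot be read: the limit of > 64 ug/mL in this assay, at which 4 of the 4 values shown sit.

The compounds shown leave open at what concentration any of them reaches half-maximal inhibition, and whether the groups on the oxygen differ at all in this assay.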